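The source may report more compounds than this note shows. Statements on the series, on what has been measured and on what is new or still open speak of the compounds shown alone.

Measured so far:
compound 1 `CCN(C(=O)c1c(O)c2c(Br)cccc2n(C)c1=O)c1ccccc1` — 95%
compound 2 `COc1cccc2c1c(O)c(C(=O)N(C)c1c(F)cccc1F)c(=O)n2C` — 43%

In a functional assay on the whole organism for inhibition, with Mus musculus as the target, at a dose of 1 mg/kg by the oral route (a higher number here means more inhibition at the dose given (going by the name of the read-out), a lower number less inhibition), compound 1 gives 95%, while compound 2 gives 43%. Compound 2 stands lowest of the two numbers, with compound 1 higher by a gap beyond the scatter. Going by the values given here, no pair of measured compounds differing in one place is available, so no measured step guides the next change.

Compound 3 `COc1cccc2c1c(O)c(C(=O)N(C)c1ccc(F)cc1F)c(=O)n2C` differs from compound 2 by 2,4-difluorophenyl in place of 2,6-difluorophenyl on an amide-type nitrogen. Among the compounds with values here, no measured pair shows this rearrangement, so the expected step in this assay is small, in no clear direction, and likely within the scatter. Compound 3 is expected to give 45%, in the range 15% to 75%. The expected step is a number 2 percentage points higher from compound 2 to compound 3 (within the scatter).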

Compound 3, a percentage reported as inhibition, in the whole organism at one dose (the size of the read-out at that dose, not a potency): 88%
Compound 3: the middle estimate sits 43 percentage points below what was measured; measured number outside the range, above it.
By their numbers in this assay, from the lowest: compound 2; then compounds 3 and 1 (each within the scatter of the next).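

In this assay, the step of a number 45 percentage points higher from compound 2 to compound 3 (beyond the scatter) comes with 2,4-difluorophenyl in place of 2,6-difluorophenyl on an amide-type nitrogen. Going by these compounds alone, both groups have the same atom counts, so at this position the arrangement of the two fluorines alone separates the two results, which the earlier compounds could not show. No measured data account for the size of this step.

From the compounds shown here alone, whether a chlorophenyl or pyridyl group on this nitrogen would match 2,4-difluorophenyl remains open. So does whether the same change would give a similar step with other groups on the shared core.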